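Swapping the Ring Nitrogen Cap from 2-Fluorophenyl to Methyl

The compounds below may be only part of what the source reports. "The series", "measured", "known", "first", "only" and "open" are said of these compounds alone.

Of the compounds shown here, three sharing one core have been tested in a functional assay on A-375 cells (Homo sapiens) for antiproliferative activity, read by CCK-8 assay, with a stated time of 72 h, tested at 8 uM; on this read-out higher numbers stand for a stronger effect at the one concentration tested and lower numbers for a weaker effect. Compound 1 `Nc1ccccc1NC(=O)c1ccc(CSC(=S)N2CCN(c3ccc(Cl)cc3)CC2)cc1` gives 29%. Compound 2 `CC1CCN(C(=S)SCc2ccc(C(=O)Nc3ccccc3N)cc2)CC1` gives 87.4%. Compound 3 `Nc1ccccc1NC(=O)c1ccc(CSC(=S)N2CCN(c3ccccc3F)CC2)cc1` gives 79.5%. Going by the values given here, compound 3 thus stands second highest of the three numbers; its gap to compound 2 lies within the scatter, while the only measured single-point step, a number 50.5 percentage points higher from compound 1 to compound 3 (beyond the scatter), lies well beyond it.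

Compound 4 `CN1CCN(C(=S)SCc2ccc(C(=O)Nc3ccccc3N)cc2)CC1` is not yet measured. It differs from compound 3 in one place: methyl in place of 2-fluorophenyl on an amine nitrogen in a ring. Among the compounds with values here, no measured step exchanges a six-membered aromatic ring for a methyl on this ring nitrogen, so the step from compound 1 to compound 3 bears on it only loosely, showing that the group on this nitrogen can shift the read-out by a large amount. Compound 2 lacks any aromatic ring at that end yet gives 87.4%, which suggests such a ring is not needed for a strong effect. The expected step is therefore a number 7.5 percentage points lower from compound 3 to compound 4 (within the scatter), none beyond the scatter. Compound 4 is estimated to give 72%, with a range from 45% to 90%.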

Compound 4, a percentage reported as inhibition, at one concentration (the size of the read-out at that concentration, not a potency): 91.6%
For compound 4 the middle estimate is 19.6 percentage points below the measured one; measured number above the stated range.
By their numbers in this assay, from the lowest: compound 1; then compounds 3, 2 and 4 (each within the scatter of the next, the first and the last beyond it).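

Replacing 2-fluorophenyl with methyl on this ring nitrogen gives a number 12.1 percentage points higher from compound 3 to compound 4 (beyond the scatter) in this assay, and replacing 4-chlorophenyl with methyl gives a number 62.6 percentage points higher from compound 1 to compound 4 (beyond the scatter), so an aromatic ring on this nitrogen is not needed for a strong effect, and here the methyl outperforms both aromatic groups. Exchanging 4-methylpiperidin-1-yl for 4-methylpiperazin-1-yl gives a number 4.2 percentage points higher from compound 2 to compound 4 (within the scatter), so these two methyl-bearing rings cannot be told apart on this read-out. Nothing available explains why these groups differ.

Going by these compounds, it remains open how a plain hydrogen, an ethyl or an acetyl on this ring nitrogen would compare with methyl. Each read-out comes from a single concentration. The close values of compound 2 and compound 4 say nothing about their relative potency.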